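The source may report more compounds than this note shows. Statements on the series, on what has been measured and on what is new or still open speak of the compounds shown alone.

Of the compounds shown here, three sharing one core have been measured in a functional assay on A549 cells (Homo sapiens) for cytotoxicity, with a stated time of 48 h; a lower number here means a stronger inhibitor, a higher number a weaker inhibitor. Compound 1, `CC(C)COc1ccc2oc(/C=C/[S+](C)[O-])cc(=O)c2c1`, gives 1100 nM. Compound 2, `C[S+]([O-])/C=C/c1cc(=O)c2cc(F)ccc2o1`, gives 2100 nM in this assay. Compound 3, `CCCCCOc1ccc2oc(/C=C/[S+](C)[O-])cc(=O)c2c1`, gives 1600 nM, the second highest of the three numbers; the step of a 1.5-fold higher number from compound 1 to compound 3 (0.16 log units; within the scatter) and the step of a 1.3-fold lower number from compound 2 to compound 3 (0.12 log units; within the scatter) both lie within the scatter, so nothing separates compound 3 from its neighbours. Compound 4, `C[S+]([O-])/C=C/c1cc(=O)c2cc(OC(=O)C(C)(C)C)ccc2o1`, has not yet been measured. It differs from compound 3 in one place: (tert-butyl)carbonyl in place of pentyl on an oxygen on an aromatic ring. Among the compounds with values here, two measured steps bear on this position. The step of a 1.5-fold higher number from compound 1 to compound 3 (0.16 log units; within the scatter) changed the chain on the aromatic oxygen, and the step of a 1.3-fold lower number from compound 2 to compound 3 (0.12 log units; within the scatter) replaced fluoro by pentyloxy; neither moved the number beyond the scatter. Within the data shown here, no measured compound carries the entering (tert-butyl)carbonyl group, so its own effect is unknown. The step is therefore expected to be no change at the digits printed from compound 3 to compound 4 (within the scatter), nothing beyond the scatter. Compound 4 is estimated at 1600 nM, within a range from 700 nM to 3600 nM.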

Compound 4, half-maximal inhibitory concentration: 1600 nM
Estimate against measurement, compound 4: no gap at the digits printed; low and high end bracket the measured number.
By their numbers in this assay, from the lowest: compounds 1, 3, 4 and 2 (each within the scatter of the next).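

In this assay, putting (tert-butyl)carbonyl in place of pentyl on the oxygen on the aromatic ring gives no change at the digits printed from compound 3 to compound 4 (within the scatter), so a group with a carbonyl on this oxygen, unlike the plain chains seen there before, still gives a number within the scatter of theirs. The comparison with the fluoro compound reads a 1.3-fold lower number from compound 2 to compound 4 (0.12 log units; within the scatter), and the comparison with the isobutyl chain reads a 1.5-fold higher number from compound 1 to compound 4 (0.16 log units; within the scatter). This position has now taken an ether, an ester and a fluoro without any step leaving the scatter, and no order can be drawn among the four compounds.

As far as these compounds go, whether a free hydroxyl, a chain ending in an amine or a carboxylic acid at this place would move the number beyond the scatter stays open. Nothing offered here accounts for this flat result.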